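This account rests on a few compounds, and the source may have more. Where it says the series, first, only, none or still open, it means among the compounds named here.

Measured compounds:
Compound 1, `COc1ccc(NS(C)(=O)=O)c2c1C(c1c[nH]cn1)CCC2`, in an assay on isolated protein for binding affinity to Alpha-1D adrenergic receptor (Rattus norvegicus), read by radioligand binding (a higher number here means a weaker inhibitor, a lower number a stronger inhibitor), gives a limit of the assay, < 10000 nM.
Compound 2, `CS(=O)(=O)Nc1ccc(F)c2c1CCCC2c1c[nH]cn1`, in this assay gives 3020 nM.

Compound 2 stands on the only number shown in this assay; the remaining value, that of compound 1, is a limit, (the limit of < 10000 nM in this assay, at which 1 of the 2 values shown sits). The step from compound 1 to compound 2, a step that the limit leaves unreadable from compound 1 to compound 2, is a fluoro in place of methoxy on an aromatic carbon, and its size cannot be read. Compound 3, `CS(=O)(=O)Nc1ccc(Cl)c2c1CCCC2c1c[nH]cn1`, has not yet been measured in this assay. It differs from compound 2 by chloro in place of fluoro on an aromatic carbon. Among the compounds with values here, the one measured step concerns a different exchange at that carbon and has no readable size, so no measured step bears directly on the chloro-for-fluoro change. With nothing to point one way or the other, the step expected from compound 2 to compound 3 in this assay is a 1.2-fold lower number from compound 2 to compound 3 (0.08 log units; within the scatter), a size not beyond the usual scatter. Compound 3 is therefore estimated at 2500 nM in this assay, with a range from 800 nM to 8000 nM.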

Compound 3, inhibition constant: 2880 nM
Compound 3: the middle estimate sits 1.2-fold (0.06 log units) below what was measured, and the stated range covers the measured number.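

In this assay the aromatic carbon para to a methanesulfonamido group now carries a step that can be read, and chloro in place of fluoro there makes no difference that stands out from the scatter (a 1.0-fold lower number from compound 2 to compound 3 (0.02 log units; within the scatter)). On the shared core, the two halogens therefore go with the same level of binding at this position, which the earlier pair of compounds could not show. Compound 1 gives a limit of the assay and not a number, so the steps from compound 1 to either halogen compound cannot be read: the limit of < 10000 nM in this assay, at which 1 of the 3 values shown sits.

From the compounds shown here alone, it remains open whether another group on this aromatic carbon, such as an amine, a nitrile or a trifluoromethyl group, would move the number in this assay beyond the scatter, and how methoxy truly compares with the two halogens. Also open is what would follow if a carboxylic acid or a longer chain took the place of the methanesulfonamido group, since that group is the same in all the compounds shown.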